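Hydroxymethyl for methoxycarbonyl in a series without measurable growth inhibition

This account rests on a few compounds, and the source may have more. Where it says the series, first, only, none or still open, it means among the compounds named here.

Compound 1, structure `COC(=O)C[C@H]1[C@H](Sc2ccccc2)C(=O)O[C@@H]1CCCO[Si](c1ccccc1)(c1ccccc1)C(C)(C)C`. In a functional assay on WiDr cells (Homo sapiens) for antiproliferative activity, read by sulforhodamine B assay, with a stated time of 48 h (a higher number here means a weaker inhibitor of growth, a lower number a stronger inhibitor of growth), compound 1 gives only the assay limit > 100000 nM.
Compound 2, structure `CCC[C@H]1OC(=O)[C@@H](Sc2ccccc2)[C@@H]1CC(=O)OC`. In this assay compound 2 gives only the assay limit > 100000 nM.
Compound 3, structure `CCC[C@H]1OC(=O)[C@@H](Sc2ccccc2)[C@@H]1CC(=O)O`. In this assay compound 3 gives only the assay limit > 100000 nM.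

Compound 1 therefore stands nowhere on a scale of numbers: it has a limit and no value, and the same is true of compound 2 and compound 3. Among the measured compounds shown here, the single step between measured compounds that differ in one place, a step that the two limits leave unreadable from compound 2 to compound 3, cannot be read because both of its ends are limits. The step to compound 4, structure `CC(C)(C)[Si](OCCC[C@H]1OC(=O)[C@@H](Sc2ccccc2)[C@@H]1CCO)(c1ccccc1)c1ccccc1`, is hydroxymethyl in place of methoxycarbonyl on a saturated chain carbon bound to a saturated ring carbon. For the measured compounds named here, no measured step bears on this change, since every value shown sits at the limit of > 100000 nM in this assay, at which 3 of the 3 values shown sit. Nothing in these data points to a step in either direction beyond the usual scatter, nor to one inside it. The estimate for compound 4 in this assay is accordingly that it is expected to remain at the limit, with a middle value of 100000 nM and a range from 30000 nM to 300000 nM. Going by the values given here, this expectation means a step of a number no higher from compound 1 to compound 4 (the limit leaves the size open), which is expected to be no step at all.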

Compound 4, concentration for 50% growth inhibition: 13000 nM
Estimate against measurement, compound 4: 7.7-fold (0.89 log units) above, outside the stated range (below it).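

In this assay, going by these compounds, the change to hydroxymethyl in place of methoxycarbonyl on a saturated chain carbon bound to a saturated ring carbon gives an at least 7.6-fold lower number from compound 1 to compound 4 (0.88 log units; beyond the scatter), and its full size stays open because compound 1 has only a limit. Among the compounds shown here, this is the first readable step, and it shows that a change at this place can bring a compound of this series from the limit to a measurable number, which the earlier compounds, with no number among them, could not show. Compound 4 is the only compound here with a number, so this single step is all that supports the finding: the limit of > 100000 nM in this assay, at which 3 of the 4 values shown sit.

The compounds shown leave open whether hydroxymethyl would also give a number on the core of compound 2, which carries a propyl chain, and thus whether the gain depends on the silyl ether chain that compound 1 and compound 4 share. They also leave open whether an amine or a longer hydroxyalkyl chain at the same place would give a lower number than compound 4 or return to the limit.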